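The compounds below may be only part of what the source reports. "The series", "measured", "known", "first", "only" and "open" are said of these compounds alone.

In an assay on cells for inhibition of Amine oxidase [flavin-containing] B (Homo sapiens), read by Amplex Red, with stated times of 30 min and 45 min (a higher number here means a weaker inhibitor, a lower number a stronger inhibitor), compound 1, `C#CCCCCOc1ccc2oc(=O)c(C(=O)OC)cc2c1`, gives 123 nM. Compound 3, `COC(=O)c1cc2cc(OCc3cccc(Cl)c3)ccc2oc1=O`, shares its core and differs from it in one place, (3-chlorophenyl in place of pent-4-yn-1-yl on a saturated chain carbon bound to an oxygen on an aromatic ring), and in this assay compound 3 gives 31.5 nM. That single change carries a 3.9-fold lower number from compound 1 to compound 3 (0.59 log units; beyond the scatter), a step that lies beyond the usual scatter of repeated measurements.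

Compound 2, `C#CCCCCOc1ccc2cc(NC(C)=O)c(=O)oc2c1`, is built on a different core; the difference between the two cores is not broken down here. In this assay compound 2 gives 41.7 nM, a number that sits within the scatter of compound 3 and beyond it from compound 1.

Compound 4, `CC(=O)Nc1cc2ccc(OCc3cccc(Cl)c3)cc2oc1=O`, has not yet been measured. It stands to compound 2 as compound 3 stands to compound 1: 3-chlorophenyl in place of pent-4-yn-1-yl on a saturated chain carbon bound to an oxygen on an aromatic ring. The place is described in the same words in both pairs, so this is the same change made a second time, now on the core of compound 2.

Among the compounds shown, the change has been measured only once, from compound 1 to compound 3, so the expectation for compound 4 rests on that single step. Because compound 2 already gives 41.7 nM and the earlier change gave a 3.9-fold lower number from compound 1 to compound 3 (0.59 log units; beyond the scatter), the step from compound 2 to compound 4 is expected to be about a 3.2-fold lower number from compound 2 to compound 4 (0.51 log units; beyond the scatter), with some allowance for the change being carried by a different core. The value of compound 4 in this assay is accordingly estimated at 13 nM, expected to fall between 5 nM and 35 nM.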

Compound 4, half-maximal inhibitory concentration: 13.5 nM
Compound 4: middle estimate off by 1.0-fold (0.02 log units), on the low side; the range from low to high includes it.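

In this assay the replacement of pent-4-yn-1-yl by 3-chlorophenyl, now read on the core of compound 2, comes to a 3.1-fold lower number from compound 2 to compound 4 (0.49 log units; beyond the scatter), and it can be set directly beside the step on the core of compound 1: the same change on two cores in this assay, a 3.9-fold lower number (0.59 log units; beyond the scatter) from compound 1 to compound 3 and a 3.1-fold lower number (0.49 log units; beyond the scatter) from compound 2 to compound 4, 1.3-fold (0.10 log units) apart, within the scatter of two such steps On these two cores, then, the change from hex-5-yn-1-yl to 3-chlorobenzyl carries over, lowering the number by amounts that cannot be told apart, and these pairs give no sign that the core alters its size. Among the compounds shown here, this rests on only two pairs in a single assay, so it does not show that the change would carry to any further core, and it gives no reason for the lower number.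

On these data alone, it remains open whether the chlorine contributes to the step, or whether a plain benzyl group, or a benzyl group carrying fluorine or bromine instead, would give a step of the same size. As far as these compounds go, it is also open whether the change would carry over equally on a core bearing a carboxylic acid or an amine in place of the methyl ester or the acetamide group.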